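This account rests on a few compounds, and the source may have more. Where it says the series, first, only, none or still open, it means among the compounds named here.

Measured compounds in a functional assay on A-375 cells (Homo sapiens) for antiproliferative activity, read by MTT assay, with a stated time of 48 h; a lower number here means a stronger inhibitor, a higher number a weaker inhibitor:
- compound 1 `CCCCCc1nc(N)n(CC(=O)Nc2ccccc2)c1-c1ccccc1Br`, giving 26400 nM
- compound 2 `CCCCCCCc1nc(N)n(CC(=O)Nc2ccccc2)c1-c1ccccc1Br`, giving 9200 nM
- compound 3 `Cc1ccc(Cc2nc(N)n(CC(=O)Nc3ccccc3)c2-c2ccccc2Br)cc1`, giving 2500 nM

Compound 2 holds the second highest of these three numbers: compound 1 lies higher, by a 2.9-fold lower number from compound 1 to compound 2 (0.46 log units; beyond the scatter), and compound 3 lies lower, by a 3.7-fold lower number from compound 2 to compound 3 (0.57 log units; beyond the scatter). Compound 4 `CC(C)(C)c1ccc(Cc2nc(N)n(CC(=O)Nc3ccccc3)c2-c2ccccc2Br)cc1` has not yet been measured. Its difference from compound 2 is 4-(tert-butyl)phenyl in place of hexyl on a saturated chain carbon bound to an aromatic carbon. The step that bears on it most directly is a 3.7-fold lower number from compound 2 to compound 3 (0.57 log units; beyond the scatter), where a 4-methylphenyl also replaced hexyl at the same place; the step of an 11-fold lower number from compound 1 to compound 3 (1.02 log units; beyond the scatter) points the same way. Compound 4 is therefore expected to show a modest step in this assay downward, about a 3.7-fold lower number from compound 2 to compound 4 (0.57 log units; beyond the scatter). The estimated value for compound 4 is 2500 nM, within 900 nM to 7000 nM.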

Compound 4, half-maximal inhibitory concentration: 2800 nM
Beside the measured number, compound 4's estimate is 1.1-fold (0.05 log units) below it; measured number inside the range.
By their numbers in this assay, from the lowest: compounds 3 and 4 (each within the scatter of the next); then compound 2; then compound 1.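

In this assay the aryl group at this place keeps its advantage over the saturated chains even with tert-butyl on the ring, giving a 3.3-fold lower number from compound 2 to compound 4 (0.52 log units; beyond the scatter) and a 9.4-fold lower number from compound 1 to compound 4 (0.97 log units; beyond the scatter) as the steps. Tert-butyl in place of methyl on the aromatic carbon gives a 1.1-fold higher number from compound 3 to compound 4 (0.05 log units; within the scatter) and so leaves the number unchanged, which shows that this aromatic carbon accepts either alkyl group in this assay. Nothing available explains this result.

On these data alone, whether an amine or a carboxylic acid on that aromatic carbon would hold the number remains open. So does the effect of plain hydrogen there.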